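Fluorobenzyl ether on the weaker quinuclidine configuration

The source may report more compounds than this note shows. Statements on the series, on what has been measured and on what is new or still open speak of the compounds shown alone.

Compound 2, `FCCOc1cccc(-c2cn([C@H]3CN4CCC3CC4)nn2)c1`: 558 nM
Compound 3, `FCCOc1cccc(-c2cn(C3CN4CCC3CC4)nn2)c1`: 20.9 nM
Compound 1, `Fc1ccc(COc2cccc(-c3cn([C@@H]4CN5CCC4CC5)nn3)c2)cc1`: 7.17 nM

In an assay on HEK293 cells for displacement of a labelled ligand from Neuronal acetylcholine receptor; alpha3/beta4 (Homo sapiens), read by scintillation counting, with a stated time of 120 min (on this read-out higher numbers stand for weaker inhibition and lower numbers for stronger inhibition), compound 2 gives 558 nM and has the highest number of the three. Going by the values given here, the only measured step that touches it runs a 27-fold lower number from compound 2 to compound 3 (1.43 log units; beyond the scatter), and the two compounds differ in nothing but a drawn configuration, so the difference in their numbers is tied to the fact that one of compounds 2 and 3 is drawn with a defined configuration and the other without, at the place where they differ.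

Compound 4, `Fc1ccc(COc2cccc(-c3cn([C@H]4CN5CCC4CC5)nn3)c2)cc1`, has not yet been measured. It keeps the drawn configuration of compound 2 and changes the ether: 4-fluorophenyl in place of fluoromethyl on a saturated chain carbon bound to an oxygen on an aromatic ring. Among the compounds with values here, no measured step changes this place on its own. Compound 1 carries the same ether as compound 4 with the other drawn configuration, and compound 1 gives 7.17 nM. Compound 3 carries the ether of compound 2 with no configuration drawn, and compound 3 gives 20.9 nM. These two values differ in two places at once, so they only hint that the benzyl ether does not hurt.

Compound 4 is therefore expected to improve on compound 2 by roughly a 2.8-fold lower number from compound 2 to compound 4 (0.45 log units; beyond the scatter), while staying well behind compound 1. The estimate for compound 4 in this assay is 200 nM, with a likely range from 50 nM to 800 nM.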

Compound 4, inhibition constant: 1090 nM
Estimate against measurement, compound 4: 5.5-fold (0.74 log units) below; measured number above the stated range.
By their numbers in this assay, from the lowest: compound 1; then compound 3; then compounds 2 and 4 (each within the scatter of the next).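

Swapping 2-fluoroethoxy for (4-fluorobenzyl)oxy on the configuration drawn in compound 2 gives a 2.0-fold higher number from compound 2 to compound 4 (0.29 log units; within the scatter) in this assay, so on this configuration, the two ethers cannot be told apart. At this place, on a saturated chain carbon bound to an oxygen on an aromatic ring, the added six-membered aromatic ring therefore shows no effect that rises above the scatter. The drawn configuration matters far more, as a 150-fold higher number from compound 1 to compound 4 (2.18 log units; beyond the scatter) is a large step between compounds with the same atoms and bonds, which ties the gap to a single stereocentre: the fact that one of compounds 1 and 4 is drawn with a defined configuration and the other without, at the place where they differ.

On these data alone, whether the choice of ether matters on the configuration of compound 1 remains open, as compound 3 has no configuration drawn and differs from compound 1 in two places. Also open, as far as these compounds go, is how this position would respond to an amine or a longer chain in place of these ethers.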